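The source may report more compounds than this note shows. Statements on the series, on what has been measured and on what is new or still open speak of the compounds shown alone.

Measured so far:
compound 1, `O=C(O)CCCSCCN1C(=O)CC[C@@H]1/C=C/[C@@H](O)Cc1cccc(OCc2ccncc2)c1`: 46 nM
compound 2, `O=C(O)c1csc(SCCN2C(=O)CC[C@@H]2/C=C/[C@@H](O)Cc2cccc(-c3ccc(Cl)cc3)c2)n1`: 27 nM

In a functional assay on CHO cells for agonist activity at prostaglandin E2 receptor EP4 subtype (Rattus norvegicus), read by cAMP accumulation and immunoassay, with a stated time of 10 min (on this read-out higher numbers stand for an effect only at larger amounts of compound and lower numbers for an effect already at smaller amounts), compound 2 gives the lowest of the two numbers, but compound 1 stands within the usual scatter of it, so no order between the two can be read from these values. Compound 3, `Cc1cccc2oc(-c3cccc(C[C@H](O)/C=C/[C@H]4CCC(=O)N4CCSc4nc(C(=O)O)cs4)c3)nc12`, differs from compound 2 in one place only: 4-methyl-1,3-benzoxazol-2-yl in place of 4-chlorophenyl on an aromatic carbon. For the measured compounds named here, no step of this kind has been measured, so any expectation rests on compound 2 alone. A step of modest size is expected here, if at all toward a smaller number, and not clearly beyond the scatter; the expected step in this assay from compound 2 to compound 3 is a 1.4-fold lower number from compound 2 to compound 3 (0.13 log units; within the scatter). For compound 3 in this assay the estimate is 20 nM, with a range from 6 nM to 70 nM.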

Compound 3, half-maximal effective concentration: 28 nM
Compound 3: the middle estimate sits 1.4-fold (0.15 log units) below what was measured; the range from low to high includes it.
By their numbers in this assay, from the lowest: compounds 2, 3 and 1 (each within the scatter of the next).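

In this assay, 4-methyl-1,3-benzoxazol-2-yl in place of 4-chlorophenyl gives a 1.0-fold higher number from compound 2 to compound 3 (0.02 log units; within the scatter), so this change leaves no difference that can be read. The aromatic carbon, meta to a large group, thus takes a group of 10 heavy atoms with 2 hydrogen-bond acceptors instead of one of 7 heavy atoms with 0 acceptors, and the number stays within the scatter. No measurement at hand bears on why the two groups read alike.

Open, as far as these compounds go, is whether the methyl group matters, which the unsubstituted 1,3-benzoxazol-2-yl group would test. Also open, from the compounds shown here alone, is how far this position tolerates other kinds of group, such as an amine or a carboxylic acid on the terminal ring, or a plain hydrogen in place of the whole aromatic group.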